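The source may hold more compounds than are shown below. What is called first, only, known or untested is meant among the compounds shown, and "the series" means these compounds.

Measured so far:
- compound 1 `Cc1ccc(N2CCn3c2n[nH]c(=O)c3=O)cc1`: 0%
- compound 2 `Cc1ccc(N2CCn3c2n[nH]c(=O)c3=N)cc1`: 0%

In an ADME assay on Vero cells (Chlorocebus sabaeus) for cytotoxicity, with a stated time of 72 h, tested at 10 ug/mL (on this read-out lower numbers stand for a weaker effect and higher numbers for a stronger effect at the one concentration tested), compound 2 gives 0%, level with compound 1 at the digits shown, the two values sitting within the scatter of each other. Compound 3 `N=c1c(=O)[nH]nc2n1CCN2c1ccc(Cl)cc1` is not yet measured; it differs from compound 2 by chloro in place of methyl on an aromatic carbon. Among the measured compounds shown here, no pair of measured compounds shows the size of such a change, so the expectation rests on both measured values sitting at the bottom of the read-out. The expected step is a number 2 percentage points higher from compound 2 to compound 3 (within the scatter), none beyond the scatter. Compound 3 is therefore estimated at 2%, with a range from 0% to 15%.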

Compound 3, a percentage reported as inhibition, at one concentration (the size of the read-out at that concentration, not a potency): 0%
Estimate against measurement, compound 3: 2 percentage points above, within the range that was stated.
By their numbers in this assay, from the lowest: compounds 1, 2 and 3 (each within the scatter of the next).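

In this assay, among the compounds shown here, chloro in place of methyl on the aromatic carbon gives no change at the digits printed from compound 2 to compound 3 (within the scatter), the first measured reading of this swap at this place on the ring. With either group, the read-out stays at the bottom of its range at the one concentration tested. Nothing measured here offers an explanation for this result. Still open, from the compounds shown here alone, is whether an amine, a carboxylic acid or a longer chain on that carbon would raise the read-out. Also open, going by these compounds, is whether chloro in place of methyl would read the same on the core of compound 1.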